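The compounds below may be only part of what the source reports. "The series", "measured", "known", "first", "only" and "open" are said of these compounds alone.

Three compounds share one core and differ at the far end of a chain: compound 1 (`C=C[C@@](C)(/C=C/c1ccc(O)cc1)CCC1OC1(C)C`), compound 2 (`C=C[C@@](C)(/C=C/c1ccc(O)cc1)CCC=O`) and compound 3 (`C=C[C@@](C)(/C=C/c1ccc(O)cc1)CC/C=C/C(=O)OCC`). In an ADME assay on BJ cells (Homo sapiens) for cytotoxicity, with a stated time of 72 h (a lower number here means that less compound is needed, a higher number that more compound is needed for the effect), compound 1 gives > 36600 nM as a limit of the assay and not a number. Compound 2 gives > 36600 nM as a limit of the same kind. Compound 3 gives > 36600 nM as a limit too. Compound 3 therefore has no number of its own and stands with the others at the limit of > 36600 nM in this assay, at which 3 of the 3 values shown sit, so far.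

Compound 4 (`C=C[C@@](C)(/C=C/c1ccc(O)cc1)CC/C=C/C#N`) keeps the core of compound 3 and makes one change, cyano in place of ethoxycarbonyl on a double-bonded chain carbon bound to a double-bonded chain carbon. The measured steps that bear on this change all lie at the same chain end (a step that the two limits leave unreadable from compound 1 to compound 2; a step that the two limits leave unreadable from compound 1 to compound 3; a step that the two limits leave unreadable from compound 2 to compound 3). None of them has a size to carry over, so none points in either direction. Resting on the step into compound 3 (a step that the two limits leave unreadable from compound 2 to compound 3) and its two neighbours, compound 4 is expected to show no change beyond the scatter and most likely the same kind of limit in this assay again. The expected step is a step that the limit leaves unreadable from compound 3 to compound 4 in this estimate. For compound 4 the estimate is 40000 nM with an expected range from 20000 nM to 80000 nM as a rough guide.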

Compound 4, half-maximal effective concentration: > 36600 nM
Compound 4: only a limit was reported; the forecaster's own chance of this, stated with the estimate: 85%; the middle value does not contradict the limit.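

No step between compound 4 and compounds 1, 2 or 3 can be read, because each value is a limit of the assay and not a number: the limit of > 36600 nM in this assay, at which 4 of the 4 values shown sit.

The compounds shown leave open what concentration of any of them would reach the half-maximal effect in this assay, and whether the changes at the chain end alter it.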